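Swapping a Chlorophenoxy Group for Anilino in Compound 4

The source may hold more compounds than are shown below. What is called first, only, known or untested is meant among the compounds shown, and "the series" means these compounds.

Compound 3 `CC(C)C[C@H](N)c1cc(C(F)(F)F)ccc1N1CCN(C(=O)COc2cccc(Cl)c2)CC1` gives the highest number of the three measured compounds in an assay on HEK293 cells for displacement of a labelled ligand from Melanocortin receptor 4 (Homo sapiens) (on this read-out higher numbers stand for weaker inhibition and lower numbers for stronger inhibition), at 2600 nM. Compound 1 `CC(C)C[C@H](N)c1cc(C(F)(F)F)ccc1N1CCN(C(=O)COc2cccc(Cl)c2Cl)CC1` gives 2500 nM in this assay, and a 1.0-fold higher number from compound 1 to compound 3 (0.02 log units; within the scatter). Compound 2 `COc1ccc(CC(C)C(=O)N2CCN(c3ccc(C(F)(F)F)cc3[C@@H](N)CC(C)C)CC2)cc1` gives 120 nM, so that a 22-fold higher number from compound 2 to compound 3 (1.34 log units; beyond the scatter). Compound 4 `CC(C)C[C@H](N)c1cc(C(F)(F)F)ccc1N1CCN(C(=O)CNc2ccccc2)CC1` differs from compound 3 by anilino in place of 3-chlorophenoxy on a saturated chain carbon bound to a carbonyl carbon. The step from compound 1 to compound 3 shows that dropping the chloro from the phenoxy ring stayed within the scatter, while the step from compound 2 to compound 3 shows that exchanging the whole group on the carbonyl carbon can move the number a great deal. Trading phenoxy for anilino is a smaller change than that, so only a modest step is expected for compound 4 in this assay, a 1.3-fold lower number from compound 3 to compound 4 (0.11 log units; within the scatter), giving an estimated 2000 nM with a range from 500 nM to 8000 nM.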

Compound 4, inhibition constant: 3600 nM
Estimate against measurement, compound 4: 1.8-fold (0.26 log units) below; measured number inside the range.
By their numbers in this assay, from the lowest: compound 2; then compounds 1, 3 and 4 (each within the scatter of the next).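

In this assay, anilino in place of 3-chlorophenoxy gives a 1.4-fold higher number from compound 3 to compound 4 (0.14 log units; within the scatter) and anilino in place of 2,3-dichlorophenoxy gives a 1.4-fold higher number from compound 1 to compound 4 (0.16 log units; within the scatter) as its step, so the phenoxy groups and anilino cannot be told apart at this position. Compound 2 keeps its distance from this new group too, with a 30-fold higher number from compound 2 to compound 4 (1.48 log units; beyond the scatter) as the step, and so 1-(4-methoxybenzyl)ethyl alone stands out among these groups. Still open, from the compounds shown here alone, is how a carboxylic acid, a primary amine or a longer chain would fare on this saturated chain carbon. Nothing shown here explains why these steps are small or large.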